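The compounds below may be only part of what the source reports. "The series", "measured", "known", "first", "only" and "open" are said of these compounds alone.

Measured compounds:

Compound 1 `Cc1ccc(-c2nc(NOC(=O)c3ccccc3)c3cc(Cl)ccc3n2)cc1`: in a functional assay on HepG2 cells (Homo sapiens) for antiproliferative activity, read by MTT assay, with a stated time of 48 h (a higher number here means a weaker inhibitor, a lower number a stronger inhibitor), compound 1 gives 12.1 ug/mL.
Compound 2 `Cc1ccc(-c2nc3ccc(Cl)cc3c(=O)n2N)cc1`: in this assay compound 2 gives 18.4 ug/mL.
Compound 3 `CSc1nc(-c2ccc(C)cc2)nc2ccc(Cl)cc12`: in this assay compound 3 gives 13.3 ug/mL.

Compound 3 holds the second highest of the three numbers, yet its gaps to compound 1 and to compound 2 both lie within the usual scatter, so none of the three can be told apart on these data. Compound 4 `Cc1ccc(-c2nc(SCCO)c3cc(Cl)ccc3n2)cc1` differs from compound 3 in one place: hydroxymethyl in place of hydrogen on a saturated chain carbon bound to a sulfur; read one bond further out, methylsulfanyl becomes (2-hydroxyethyl)sulfanyl. Within the data shown here, no measured pair shows this change, so its size is unknown here. The step from compound 3 to compound 4 in this assay is expected to be a 1.1-fold higher number from compound 3 to compound 4 (0.02 log units; within the scatter), in no sure direction and not beyond the scatter. Compound 4 is therefore estimated at 14 ug/mL, with a range from 6 ug/mL to 32 ug/mL.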

Compound 4, half-maximal inhibitory concentration: 9.04 ug/mL
Beside the measured number, compound 4's estimate is 1.5-fold (0.19 log units) above it; measured number inside the range.
By their numbers in this assay, from the lowest: compounds 4, 1, 3 and 2 (each within the scatter of the next, the first and the last beyond it).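

Going from methylsulfanyl to (2-hydroxyethyl)sulfanyl gives the only direct reading of this position: in this assay there is a 1.5-fold lower number from compound 3 to compound 4 (0.17 log units; within the scatter). Adding hydroxymethyl on the saturated chain carbon bound to a sulfur therefore leaves the number within the scatter, so the position accepts this larger, hydroxyl-bearing group without a clear loss or gain. Nothing measured here explains this result. As far as these compounds go, it remains open whether an amine or a carboxylic acid in place of this hydroxymethyl, or a longer chain on the sulfur, would move the number beyond the scatter.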